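The source may report more compounds than this note shows. Statements on the series, on what has been measured and on what is new or still open speak of the compounds shown alone.

Three compounds sharing one bicyclic lactam core, each carrying a different aryl group on the triazole nitrogen, have been measured in a functional assay on PANC-1 cells (Homo sapiens) for inhibition, read by MTT assay, with a stated time of 24 h; on this read-out higher numbers stand for weaker inhibition and lower numbers for stronger inhibition. Compound 1 `CC1(C)[C@H]2CC[C@]1(C)N(Cc1cn(-c3ccccc3Br)nn1)C(=O)C2` gives 280 nM. Compound 2 `CC1(C)[C@H]2CC[C@]1(C)N(Cc1cn(-c3ccc(C#N)cc3)nn1)C(=O)C2` gives 250 nM. Compound 3 `CC1(C)[C@H]2CC[C@]1(C)N(Cc1cn(-c3ccc(O)cc3)nn1)C(=O)C2` gives 100 nM. Among these three numbers compound 2 stands second highest: the step of a 1.1-fold lower number from compound 1 to compound 2 (0.05 log units; within the scatter) lies within the scatter, while the step of a 2.5-fold lower number from compound 2 to compound 3 (0.40 log units; beyond the scatter) is modest but real, and the step of a 2.8-fold lower number from compound 1 to compound 3 (0.45 log units; beyond the scatter) points the same way.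

The next compound, compound 4 `Cc1cccc(-n2cc(CN3C(=O)C[C@@H]4CC[C@@]3(C)C4(C)C)nn2)c1`, differs from compound 2 only in the aryl group: 3-methylphenyl in place of 4-cyanophenyl on an aromatic nitrogen. For the measured compounds named here, the steps that bear on this change are those that also swap the aryl group, a 1.1-fold lower number from compound 1 to compound 2 (0.05 log units; within the scatter) and a 2.5-fold lower number from compound 2 to compound 3 (0.40 log units; beyond the scatter). Only the hydroxyl-bearing compound 3 moved beyond the scatter; the two other aryl groups gave numbers within the scatter of each other. Compound 4 is therefore expected to show a step of about a 1.1-fold higher number from compound 2 to compound 4 (0.03 log units; within the scatter), that is no change beyond the scatter. In this assay compound 4 is estimated at 270 nM, with a range from 120 nM to 600 nM.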

Compound 4, half-maximal inhibitory concentration: 240 nM
For compound 4 the middle estimate is 1.1-fold (0.05 log units) above the measured one, within the range that was stated.
By their numbers in this assay, from the lowest: compound 3; then compounds 4, 2 and 1 (each within the scatter of the next).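

In this assay the change from 4-cyanophenyl to 3-methylphenyl removes the nitrile and its one hydrogen-bond acceptor, yet a 1.0-fold lower number from compound 2 to compound 4 (0.02 log units; within the scatter) shows no change beyond the scatter. The 2-bromophenyl compound gives the same picture, with a 1.2-fold lower number from compound 1 to compound 4 (0.07 log units; within the scatter) also within the scatter, so three differently substituted phenyl groups on this aromatic nitrogen now give numbers that cannot be told apart, while a 2.4-fold higher number from compound 3 to compound 4 (0.38 log units; beyond the scatter) is a modest but real step that leaves the 4-hydroxyphenyl of compound 3 alone as the stronger inhibitor. Nothing available explains why this one group stands apart. Going by these compounds, it remains open whether an amine or a carboxylic acid on the phenyl ring would match compound 3 or the other three. A longer chain or a ring without an aryl group at this nitrogen is also untested in what is shown here.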